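Moving the tert-butyl group around the phenoxy ring

The source may report more compounds than this note shows. Statements on the series, on what has been measured and on what is new or still open speak of the compounds shown alone.

Three compounds share one core and differ only in the aryl group carried on an oxygen on a saturated carbon. Compound 1 `COc1cc2c(cc1OC)CN(CCn1cc(COc3cccc4ccccc34)nn1)CC2` gives in an ADME assay on K562 cells (Homo sapiens) for cytotoxicity, read by MTT assay, with a stated time of 48 h (a lower number here means a stronger inhibitor, a higher number a weaker inhibitor), a value of > 100000 nM, which is a limit of the assay. Compound 2 `COc1cc2c(cc1OC)CN(CCn1cc(COc3ccc(C)cc3)nn1)CC2` gives in this assay > 100000 nM, again only a limit. Compound 3 `COc1cc2c(cc1OC)CN(CCn1cc(COc3ccc(C(C)(C)C)cc3)nn1)CC2` likewise reaches only a limit in this assay, at > 100000 nM. The steps a step that the two limits leave unreadable from compound 1 to compound 2, a step that the two limits leave unreadable from compound 1 to compound 3 and a step that the two limits leave unreadable from compound 2 to compound 3 cannot be sized because the limit of > 100000 nM in this assay, at which 3 of the 3 values shown sit, covers every value measured. Compound 4 `COc1cc2c(cc1OC)CN(CCn1cc(COc3ccccc3C(C)(C)C)nn1)CC2` differs from compound 3 by 2-(tert-butyl)phenyl in place of 4-(tert-butyl)phenyl on an oxygen on a saturated carbon. Among the measured compounds shown here, no measured step speaks readably to this change, so compound 4 is expected to remain at the limit as well, estimated at 150000 nM with a range of 50000 nM to 500000 nM. The expected step is a step that the limit leaves unreadable from compound 3 to compound 4.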

Compound 4, half-maximal inhibitory concentration: > 100000 nM
Compound 4 was reported as a limit (the forecaster's own chance of this, stated with the estimate: 85%); the middle value is on the limit's open side.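

The steps linking compound 4 to compound 1, compound 2 and compound 3 cannot be read, because all four compounds share one reading: the limit of > 100000 nM in this assay, at which 4 of the 4 values shown sit. The compounds shown leave open whether any aryl group on this core gives a measurable value in this assay.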